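The source may hold more compounds than are shown below. What is called first, only, known or untested is meant among the compounds shown, and "the series" means these compounds.

Three compounds have been measured in a functional assay on P388 cells (Mus musculus) for cytotoxicity; on this read-out lower numbers stand for stronger inhibition and higher numbers for weaker inhibition:

Compound 1 `Cc1cc(-c2c(F)cc3c(=O)ccn(C4CC4)c3c2F)cc(C)n1`: 15000 nM
Compound 2 `Cc1cc(-c2c(F)cc3c(=O)c(Cc4c(O)cccc4O)cn(C4CC4)c3c2F)cc(C)n1`: 250 nM
Compound 3 `Cc1cc(-c2c(F)cc3c(=O)c(Cc4ccc(Cl)cc4)cn(C4CC4)c3c2F)cc(C)n1`: 20000 nM

Placing a 4-chlorobenzyl group on the shared core left the number within the scatter, with a 1.3-fold higher number from compound 1 to compound 3 (0.12 log units; within the scatter). A 2,6-dihydroxybenzyl group at the same place gave a 60-fold lower number from compound 1 to compound 2 (1.78 log units; beyond the scatter). Exchanging its 2,6-dihydroxyphenyl for 4-chlorophenyl then gave an 80-fold higher number from compound 2 to compound 3 (1.90 log units; beyond the scatter). Compound 3 therefore stands level with compound 1, and both lie far from compound 2.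

Compound 4 `COc1ccc(Cc2cn(C3CC3)c3c(F)c(-c4cc(C)nc(C)c4)c(F)cc3c2=O)cc1` differs from compound 3 in one place: methoxy in place of chloro on an aromatic carbon. This is methoxy in place of chloro on an aromatic carbon, para to a large group, so 4-chlorobenzyl becomes 4-methoxybenzyl. Among the compounds with values here, no measured step makes this exchange directly. Both large steps involve the 2,6-dihydroxybenzyl group of compound 2, which compound 4 does not carry. Within the data shown here, the nearest precedent is the 4-chlorobenzyl group, whose step was small, with a 1.3-fold higher number from compound 1 to compound 3 (0.12 log units; within the scatter). No step beyond the scatter is therefore expected in this assay. The expected change is a 1.3-fold lower number from compound 3 to compound 4 (0.12 log units; within the scatter). Compound 4 is estimated at 15000 nM, with an expected range from 6000 nM to 40000 nM.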

Compound 4, half-maximal inhibitory concentration: 21000 nM
Beside the measured number, compound 4's estimate is 1.4-fold (0.15 log units) below it; measured number inside the range.
By their numbers in this assay, from the lowest: compound 2; then compounds 1, 3 and 4 (each within the scatter of the next).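

In this assay, exchanging chloro for methoxy on this aromatic carbon, para to a large group, gave a 1.1-fold higher number from compound 3 to compound 4 (0.02 log units; within the scatter), so adding a hydrogen-bond acceptor here made no difference that could be read. Placing the 4-methoxybenzyl group on the shared core likewise gave a 1.4-fold higher number from compound 1 to compound 4 (0.15 log units; within the scatter), so among the compounds shown both 4-substituted benzyl groups stand level with the unsubstituted core, and only compound 2 goes against this, while the change from its 2,6-dihydroxyphenyl to 4-methoxyphenyl gave an 84-fold higher number from compound 2 to compound 4 (1.92 log units; beyond the scatter). Nothing at hand gives a reason for this large gap between compound 2 and the other benzyl compounds.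

On these data alone, it remains open whether a 4-hydroxybenzyl or a 2,6-dimethoxybenzyl group would stand with compound 2 or with compound 4, which leaves unsettled whether the large step follows the hydroxy groups themselves or the place they occupy on the ring. As far as these compounds go, a 4-aminobenzyl group, or a benzyl group carrying a carboxylic acid, is also open, so the flat result holds only for chloro and methoxy.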